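Hydroxy to phenylsulfanyl on the sulfonylated core

A few compounds are considered here, and "the series" means these few. Any claim that something is new, unique, unknown or untested is made for them only; others in the source may bear on it.

Three compounds of the series have numbers in a functional assay on MCF7 cells (Homo sapiens) for antiproliferative activity; a lower number here means a stronger inhibitor, a higher number a weaker inhibitor. Compound 1 `c1ccc(Sc2ncnc3ncn(C4CNc5ccccc5CO4)c23)cc1` carries a free ring nitrogen and gives 48900 nM. Among the measured compounds shown here, compound 2 `O=[N+]([O-])c1ccc(S(=O)(=O)N2CC(n3cnc4ncnc(Sc5ccccc5)c43)OCc3ccccc32)cc1` gives 860 nM, and the step of a 57-fold lower number from compound 1 to compound 2 (1.75 log units; beyond the scatter) is the one measured change in the set. Compound 3 `O=[N+]([O-])c1ccccc1S(=O)(=O)N1CC(n2cnc3ncnc(O)c32)OCc2ccccc21` gives 19700 nM; it stands second highest of the three, beyond the scatter from compound 1 on one side and far from compound 2 on the other.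

Compound 4 `O=[N+]([O-])c1ccccc1S(=O)(=O)N1CC(n2cnc3ncnc(Sc4ccccc4)c32)OCc2ccccc21` is the next compound, differing from compound 3 by phenylsulfanyl in place of hydroxy on an aromatic carbon. For the measured compounds named here, no measured step covers this exchange directly: the hydroxy appears only in compound 3, and compounds 1 and 2 both carry phenylsulfanyl at that position. What can be said is that compound 2 and compound 4 share the phenylsulfanyl and a (nitrophenyl)sulfonyl on the ring nitrogen, differing only in where the nitro sits, and that compound 2 shows a much lower number than compound 3. On these data alone, a sizeable downward step is therefore expected, a 13-fold lower number from compound 3 to compound 4 (1.12 log units; beyond the scatter), though how much of the gap between compound 3 and compound 2 the phenylsulfanyl alone accounts for is unknown. Compound 4 is estimated at 1500 nM, within 400 nM to 6000 nM.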

Compound 4, half-maximal inhibitory concentration: 2590 nM
Beside the measured number, compound 4's estimate is 1.7-fold (0.24 log units) below it, within the range that was stated.
By their numbers in this assay, from the lowest: compound 2; then compound 4; then compound 3; then compound 1.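

In this assay the exchange on this aromatic carbon now has a direct reading with the sulfonylated ring nitrogen held fixed, and a 7.6-fold lower number from compound 3 to compound 4 (0.88 log units; beyond the scatter) shows that phenylsulfanyl in place of hydroxy gives a lower number on a (2-nitrophenyl)sulfonyl core. Among the compounds shown here, the nitro placement also matters, which the earlier compounds could not show: a 3.0-fold higher number from compound 2 to compound 4 (0.48 log units; beyond the scatter) with 2-nitrophenyl in place of 4-nitrophenyl, while with phenylsulfanyl held, sulfonylation of the ring nitrogen still lowers the number with the 2-nitrophenyl group, as a 19-fold lower number from compound 1 to compound 4 (1.28 log units; beyond the scatter) shows. Nothing measured on these compounds accounts for the size of any of these steps.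

On these data alone, how far the hydroxy to phenylsulfanyl step carries over to the 4-nitrophenyl sulfonyl core or to the free ring nitrogen stays open, so its size is known on one background only. Also open, as far as these compounds go, is what an amine or a methoxy on this aromatic carbon would give in place of phenylsulfanyl, and what 3-nitrophenyl or an unsubstituted phenyl would give on the sulfonyl sulfur.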